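The compounds below may be only part of what the source reports. "The series", "measured", "known", "first", "only" and "open" are said of these compounds alone.

Measured compounds:
compound 1 `CC(=O)N[C@H]1[C@@H](OCc2ccccc2)O[C@H](CO)[C@@H](O)[C@@H]1O`; in a functional assay on C6 cells (Rattus norvegicus), read by thymidine incorporation (a lower number here means a stronger inhibitor, a higher number a weaker inhibitor), compound 1 gives > 50 uM, which is a limit of the assay.
compound 2 `CCCCC(=O)N[C@H]1[C@@H](OCCc2ccccc2)O[C@H](COCC(CO)(CO)COS(=O)(=O)O)[C@@H](O)[C@@H]1O`; in this assay compound 2 gives 8.6 uM.
compound 3 `CCCCC(=O)N[C@H]1[C@@H](OCCc2ccccc2)O[C@H](COCC(CO)(CO)CO)[C@@H](O)[C@@H]1O`; in this assay compound 3 gives > 50 uM, again a limit of the assay.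

Compound 3 therefore stands at the limit of > 50 uM in this assay, at which 2 of the 3 values shown sit, with no number of its own. Going by the values given here, the one measured step, an at least 5.8-fold higher number from compound 2 to compound 3 (0.76 log units; beyond the scatter), concerns hydrogen in place of sulfo on an oxygen on a saturated carbon; it does not touch the polyol chain and so bears on the present step only by showing that compound 3 is at the limit. Compound 4 `CCCCC(=O)N[C@H]1[C@@H](OCCc2ccccc2)O[C@H](COCC(O)CO)[C@@H](O)[C@@H]1O` differs from compound 3 by 1,2-dihydroxyethyl in place of 2-hydroxy-1,1-bis(hydroxymethyl)ethyl on a saturated chain carbon bound to an oxygen on a saturated carbon. Among the compounds with values here, no measured pair varies this part of the molecule, so no step beyond the scatter can be predicted in either direction, and since compound 3 is at the limit, compound 4 is expected to remain there, the expected step being a step that the limit leaves unreadable from compound 3 to compound 4. The estimate for compound 4 is 70 uM, within a range of 25 uM to 250 uM, most likely reported as a limit.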

Compound 4, concentration for 50% inhibition: > 50 uM
Compound 4: only a limit was reported; the forecaster's own chance of this, stated with the estimate: 75%; the middle value lies beyond the limit too.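

In this assay compound 4 gives > 50 uM, a limit of the assay. Any step between compound 3 and compound 4 cannot be read, because both sit at the same limit: the limit of > 50 uM in this assay, at which 3 of the 4 values shown sit. Against the sulfated chain, the change to 1,2-dihydroxyethyl reads as an at least 5.8-fold higher number from compound 2 to compound 4 (0.76 log units; beyond the scatter), so a second chain without sulfo, of a different size, also fails to reach a measurable number, and among the compounds shown only compound 2, the one carrying sulfo, has a value that is not a limit.

From the compounds shown here alone, how far compound 3 and compound 4 lie beyond the limit stays open, so the two polyol chains cannot be ranked. Also open, going by these compounds, is whether sulfo on the 2,3-dihydroxypropyl chain, or a carboxylic acid or phosphate in place of sulfo, would give a measurable value.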